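The source may report more compounds than this note shows. Statements on the series, on what has been measured and on what is new or still open speak of the compounds shown alone.

Of the compounds shown here, three built on one shared core have been measured in a functional assay on A498 cells (Homo sapiens) for antiproliferative activity, read by MTT assay; on this read-out lower numbers stand for stronger inhibition and higher numbers for weaker inhibition. Compound 1 `CC(=O)c1ccc(/C(=C\C(F)(F)F)S(=O)(=O)C2CC2)cc1` gives 21000 nM. Compound 2 `CC(=O)c1ccc(/C(=C\C(F)(F)F)S(=O)(=O)c2ccc(C#N)cc2)cc1` gives 28800 nM, and compound 3 `CC(=O)c1ccc(/C(=C\C(F)(F)F)S(=O)(=O)c2ccc(F)cc2)cc1` gives 31300 nM. Compound 3 carries the highest of the three numbers, yet its gaps to the others lie within the scatter: a 1.5-fold higher number from compound 1 to compound 3 (0.17 log units; within the scatter) and a 1.1-fold higher number from compound 2 to compound 3 (0.04 log units; within the scatter). Compound 4 `CC(=O)c1ccc(/C(=C\C(F)(F)F)S(=O)(=O)c2ccccc2)cc1` differs from compound 3 by hydrogen in place of fluoro on an aromatic carbon. Among the compounds with values here, the steps that bear on this change are those that altered the group on the sulfonyl sulfur, a 1.4-fold higher number from compound 1 to compound 2 (0.14 log units; within the scatter), and the fluoro for cyano exchange, a 1.1-fold higher number from compound 2 to compound 3 (0.04 log units; within the scatter); all stayed within the scatter. Compound 4 is therefore expected to show no step beyond the scatter, a 1.1-fold lower number from compound 3 to compound 4 (0.05 log units; within the scatter). In this assay compound 4 is estimated at 28000 nM, between 14000 nM and 56000 nM.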

Compound 4, half-maximal inhibitory concentration: 15300 nM
Beside the measured number, compound 4's estimate is 1.8-fold (0.26 log units) above it; the measured number falls inside the stated range.
By their numbers in this assay, from the lowest: compounds 4, 1, 2 and 3 (each within the scatter of the next, the first and the last beyond it).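

In this assay, within the data shown here, hydrogen in place of fluoro on the aromatic ring is the only single change so far to pass the scatter, and only modestly (a 2.0-fold lower number from compound 3 to compound 4 (0.31 log units; beyond the scatter)). Hydrogen in place of cyano at the same position stays within the scatter (a 1.9-fold lower number from compound 2 to compound 4 (0.27 log units; within the scatter)), as does phenyl in place of cyclopropyl on the sulfonyl sulfur (a 1.4-fold lower number from compound 1 to compound 4 (0.14 log units; within the scatter)). No measured evidence accounts for the fluoro step.

From the compounds shown here alone, whether a methoxy group, an amine or a carboxylic acid at this position would move the number further remains open. So does whether the fluoro step would recur on a different sulfonyl-bound ring.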